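A few compounds are considered here, and "the series" means these few. Any claim that something is new, unique, unknown or untested is made for them only; others in the source may bear on it.

In a functional assay on ECa-109 cells for inhibition, with ECa-109 cell line (Homo sapiens) as the target, read by sulforhodamine B assay (a lower number here means a stronger inhibitor, a higher number a weaker inhibitor), compound 1 `CCCc1ccc(NC2=CC(=O)c3nc4n(c3C2=O)[C@H]2OC[C@@H](O)[C@H]2OC4)cc1` gives only a limit, not a number: > 4000 nM. Compound 3 `COc1ccccc1NC1=CC(=O)c2c(nc3n2[C@H]2OC[C@@H](O)[C@H]2OC3)C1=O` likewise gives only a limit, > 4000 nM. Compound 1 therefore stands at the limit of > 4000 nM in this assay, at which 2 of the 3 values shown sit. Among the measured compounds shown here, compound 2 `O=C1C(Nc2ccccc2F)=CC(=O)c2c1nc1n2[C@H]2OC[C@@H](O)[C@H]2OC1` is the only one with a measured number, 2660 nM. Compound 4 `O=C1C=C(Nc2cccc(F)c2)C(=O)c2c1nc1n2[C@H]2OC[C@@H](O)[C@H]2OC1` carries 3-fluorophenyl in place of 4-propylphenyl on an amine nitrogen. For the measured compounds named here, the one measured step that bears on this is an at least 1.5-fold higher number from compound 2 to compound 3 (0.17 log units; that floor lies within the scatter), where methoxy replaces fluoro on an aromatic carbon, so it is only a weak guide. Since fluoro-bearing compound 2 reads 2660 nM, a modest move towards a lower number is expected. Another limit remains possible for compound 4. The expected step is an at least 1.3-fold lower number from compound 1 to compound 4 (0.12 log units; that floor lies within the scatter). For compound 4 the estimate is 3000 nM, with an expected range of 1200 nM to 6500 nM.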

Compound 4, half-maximal inhibitory concentration: 7030 nM
The estimate for compound 4 lay 2.3-fold (0.37 log units) below the measured number, outside the stated range (above it).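

The step from compound 1 to compound 4 cannot be read, because compound 1 sits at a limit of the assay: the limit of > 4000 nM in this assay, at which 2 of the 4 values shown sit. The compounds shown leave open what 3-fluorophenyl in place of 4-propylphenyl on an amine nitrogen does to the number.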